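Benzylamine swap on the diamino core: dichloro to dimethoxy

The compounds below may be only part of what the source reports. "The series", "measured", "known", "first", "only" and "open" are said of these compounds alone.

Working notes on a small series sharing one diamino core. Compound 1 `CCOC(=O)[C@H](CCC(=O)O)NC(=O)c1ccc(CNc2nc3cc(N)cc(N)c3nc2-c2ccccc2)cc1` carries a glutamate-bearing benzyl group, and in a functional assay on UO-31 cells (Homo sapiens) for inhibition, read by sulforhodamine B assay, with a stated time of 48 h (on this read-out lower numbers stand for higher toxicity in this test and higher numbers for lower toxicity in this test), compound 1 is reported only as a limit of the assay, < 100000 nM. Compound 2 `Nc1cc(N)c2nc(-c3ccccc3)c(NCc3ccc(Cl)c(Cl)c3)nc2c1` carries a 3,4-dichlorophenyl in the same position. In this assay compound 2 likewise stands only at a limit of the assay, < 100000 nM. So compound 2 cannot be placed against compound 1 by a number: both values sit at the same boundary, as summarized by the limit of < 100000 nM in this assay, at which 2 of the 2 values shown sit, and no step between them can be counted.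

Compound 3 `COc1ccc(CNc2nc3cc(N)cc(N)c3nc2-c2ccccc2)cc1OC` is not yet measured. It differs from compound 2 by 3,4-dimethoxyphenyl in place of 3,4-dichlorophenyl on a saturated chain carbon bound to a nitrogen on an aromatic ring. For the measured compounds named here, with no measured step to lean on and both known values reported as limits, the expected step from compound 2 to compound 3 in this assay is a step that the limit leaves unreadable from compound 2 to compound 3, which here means no direction beyond the usual scatter and a fair chance that compound 3 again returns only a limit. For compound 3 the estimated value in this assay is 30000 nM, with a range from 5000 nM to 90000 nM.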

Compound 3, concentration lethal to 50% of the cells: < 100000 nM
Compound 3 gave a limit, no number (the forecaster's own chance of this, stated with the estimate: 60%); the middle value lies beyond the limit too.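

Compound 3, like compound 2, stands only at a limit of the assay, so no step between the two can be read in this assay: the limit of < 100000 nM in this assay, at which 3 of the 3 values shown sit.

The compounds shown leave open whether 3,4-dichlorophenyl and 3,4-dimethoxyphenyl differ at all in this assay, and how either compares with the glutamate-bearing group of compound 1.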